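Azetidine acrylamide after three compounds at the limit

A few compounds are considered here, and "the series" means these few. Any claim that something is new, unique, unknown or untested is made for them only; others in the source may bear on it.

Values in a functional assay on MDA-MB-231 cells (Homo sapiens) for antiproliferative activity, read by CCK-8 assay, with a stated time of 48 h (on this read-out higher numbers stand for weaker inhibition and lower numbers for stronger inhibition), follow.
compound 1 `C=C(C)C(=O)NCCOc1ccc(Oc2c(-c3ccc(F)cc3)sc3cc(O)ccc23)cc1` gives > 50000 nM
compound 2 `C/C=C/C(=O)N1CC(Oc2ccc(Oc3c(-c4ccc(F)cc4)sc4cc(O)ccc34)cc2)C1` gives > 50000 nM
compound 3 `O=C(CCCNCCOc1ccc(Oc2c(-c3ccc(F)cc3)sc3cc(O)ccc23)cc1)N1CCC1` gives > 50000 nM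

Each of these three values is a limit and not a number. Compound 3 stands with the other two at the limit of > 50000 nM in this assay, at which 3 of the 3 values shown sit, and so has no rank within the series.

Compound 4 `C=CC(=O)N1CC(Oc2ccc(Oc3c(-c4ccc(F)cc4)sc4cc(O)ccc34)cc2)C1` differs from compound 3 by 1-(vinylcarbonyl)azetidin-3-yl in place of 2-((3-((azetidin-1-yl)carbonyl)propyl)amino)ethyl on an oxygen on an aromatic ring and keeps the shared core.

The measured steps are a step that the two limits leave unreadable from compound 1 to compound 2 and a step that the two limits leave unreadable from compound 1 to compound 3 and a step that the two limits leave unreadable from compound 2 to compound 3 and none of them gives a size or direction.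

The nearest guide is compound 2 with 1-((prop-1-en-1-yl)carbonyl)azetidin-3-yl on the same oxygen, and its > 50000 nM is again a limit. Compound 4 is therefore expected to remain near that limit. The expected change is a number no higher from compound 3 to compound 4 (the limit leaves the size open) and no step beyond the scatter can be forecast.

The estimate for compound 4 is 50000 nM with an expected range from 20000 nM to 80000 nM in this assay as tested.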

Compound 4, half-maximal inhibitory concentration: > 50000 nM
Compound 4 ended at the assay's limit; the forecaster's own chance of this, stated with the estimate: 70%; the middle value sits exactly at the limit.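

Compound 4 gives a limit and not a number, as do compound 1, compound 2 and compound 3, so no step among these four can be read in this assay. All four share one value: the limit of > 50000 nM in this assay, at which 4 of the 4 values shown sit.

The compounds shown leave open how strongly any of them inhibits and whether any group on that oxygen changes the read-out.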